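Swapping the Aryl Group on the Amine of a Hydroxamate Core

The source may hold more compounds than are shown below. What is called first, only, known or untested is meant among the compounds shown, and "the series" means these compounds.

Among the compounds with values here, compound 2 `C#Cc1cccc(Nc2ncnc3cc(NC(=O)CCCCCCC(=O)NO)sc23)c1` gives 21.3 nM in an assay on cells for inhibition of protein deacetylase HDAC6 (Homo sapiens), with a stated time of 3 h (on this read-out higher numbers stand for weaker inhibition and lower numbers for stronger inhibition), the lower of the two numbers known so far. Compound 1 `Cc1cc(F)ccc1Nc1ncnc2cc(NC(=O)CCCCCCC(=O)NO)sc12` gives 120 nM in this assay, and a 5.6-fold lower number from compound 1 to compound 2 (0.75 log units; beyond the scatter). Compound 3 `CCc1ccc(Nc2ncnc3cc(NC(=O)CCCCCCC(=O)NO)sc23)cc1` differs from compound 2 in that (4-ethylphenyl in place of 3-ethynylphenyl on a nitrogen on an aromatic ring). Within the data shown here, only that one measured step bears on this change, and it shows that exchanging the group on this nitrogen can move the number modestly. A small shift toward a higher number is therefore expected, a 1.9-fold higher number from compound 2 to compound 3 (0.27 log units; within the scatter). In this assay compound 3 is estimated at 40 nM, within 12 nM to 130 nM.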

Compound 3, half-maximal inhibitory concentration: 98.3 nM
Compound 3: the middle estimate sits 2.5-fold (0.39 log units) below what was measured, and the stated range covers the measured number.
By their numbers in this assay, from the lowest: compound 2; then compounds 3 and 1 (each within the scatter of the next).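

With a 4.6-fold higher number from compound 2 to compound 3 (0.66 log units; beyond the scatter) in this assay the 4-ethylphenyl group does not keep the level seen with 3-ethynylphenyl, although both groups hold 8 heavy atoms. With a 1.2-fold lower number from compound 1 to compound 3 (0.09 log units; within the scatter) the 4-ethylphenyl and 4-fluoro-2-methylphenyl groups cannot be told apart, so of the three groups on this nitrogen only 3-ethynylphenyl stands apart. On these data alone, whether a 3-ethylphenyl, 4-ethynylphenyl or unsubstituted phenyl group would side with compound 2 or with the other two remains open, so the triple bond and the place of the group are not separated here. No outside evidence bears on this result.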